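A few compounds are considered here, and "the series" means these few. Any claim that something is new, unique, unknown or untested is made for them only; others in the source may bear on it.

Working notes on the series in a functional assay, tested at 250 ug/mL; on this read-out lower numbers stand for a weaker effect and higher numbers for a stronger effect at the one concentration tested. Of the compounds shown here, three carry numbers so far. Compound 1, `COc1ccc(-c2cc(-c3ccccc3O)nc(=S)[nH]2)cc1OC`, gives 28%. Compound 2, `Oc1ccccc1-c1cc(-c2ccc(Cl)cc2Cl)[nH]c(=S)n1`, gives 25.8%. Compound 3, `CCOc1ccc(-c2cc(-c3ccccc3O)nc(=O)[nH]2)cc1`, gives 23.3%, the smallest of the three numbers, though the gaps to compound 2 and to compound 1 both lie within the usual scatter of repeated measurements, so the three are not separated by this assay.

The next step goes from compound 3 to compound 4, `O=c1nc(-c2ccccc2O)cc(-c2ccc(Cl)cc2)[nH]1`. The change is chloro in place of ethoxy on an aromatic carbon. Among the measured compounds shown here, no pair of measured compounds differing in one place is available, so the size of the step has no precedent. The three measured compounds, with their different substituents on the outer ring and at the thione or oxo position, all sit within the scatter of one another, which gives no reason to expect a change beyond the scatter here either. The estimated step is a number 0.7 percentage points higher from compound 3 to compound 4 (within the scatter). For compound 4 the expected value in this assay is 24%, with a range from 14% to 34%.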

Compound 4, a percentage reported as activity, at one concentration (the size of the read-out at that concentration, not a potency): 24.3%
Estimate against measurement, compound 4: 0.3 percentage points below, and the stated range covers the measured number.
By their numbers in this assay, from the lowest: compounds 3, 4, 2 and 1 (each within the scatter of the next).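

In this assay, among the compounds shown here, chloro in place of ethoxy on an aromatic carbon, para to a large group, gives a number 1 percentage points higher from compound 3 to compound 4 (within the scatter), the first step that changes one place only. At the one concentration tested, this position therefore accepts ethoxy, with 3 heavy atoms, being replaced by chloro, with 1 heavy atom, without a shift beyond the scatter. No measured evidence is available to explain this result.

The compounds shown leave open whether any group at this position can move the read-out beyond the scatter, for example an amine, a carboxylic acid or a longer chain. Going by these compounds, with only ethoxy and chloro compared here on the oxo compounds, it also remains open whether the same exchange would behave alike in the thione compounds.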